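The compounds below may be only part of what the source reports. "The series", "measured", "known", "first", "only" and "open" are said of these compounds alone.

Working notes on the thiourea series. Compound 1 `NC(=S)N1CCC(c2ccc(F)cc2)=N1` is reported in an in vitro assay on cells for inhibition of Amine oxidase [flavin-containing] B (Homo sapiens), read by Amplex Red, with a stated time of 15 min, tested at 100 uM (on this read-out lower numbers stand for less inhibition and higher numbers for more inhibition at the one concentration tested (going by the name of the read-out)), as "not active" (no number reported), without a number. Compound 2 `CNC(=S)N1CCC(c2ccccc2C)=N1` is reported in this assay likewise as "not active" (no number reported). Going by the values given here, compound 3 `CNC(=S)N1CC(C)C(c2ccc(F)cc2)=N1` is the one member with a number: in this assay compound 3 gives 40%, the only figure on record. Compound 4 `CC1CN(C(N)=S)N=C1c1ccc(F)cc1` remains to be measured. Compound 4 differs from compound 3 by hydrogen in place of methyl on an amide-type nitrogen. Among the compounds with values here, no two measured compounds differ in one place, so no measured step fixes the size of this change. Compound 1 also carries hydrogen on the amide-type nitrogen and shows "not active" (no number reported) in this assay, whereas compound 3 shows 40%. A loss beyond the scatter is therefore expected, estimated as a number 22 percentage points lower from compound 3 to compound 4 (beyond the scatter). Compound 4 is expected at 18% in this assay, within 3% to 38%.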

Compound 4, a percentage reported as inhibition, at one concentration (the size of the read-out at that concentration, not a potency): 40%
Beside the measured number, compound 4's estimate is 22 percentage points below it; measured number outside the range, above it.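

In this assay, hydrogen in place of methyl on the amide-type nitrogen gives no change at the digits printed from compound 3 to compound 4 (within the scatter), so with the core of compound 3 the number is level with either group on this nitrogen. Compound 4 gives 40% while compound 1 is reported as "not active" (no number reported), so hydrogen on this nitrogen does not by itself go with a "not active" report. No measurement on hand explains the absence of a step here.

Going by these compounds, whether a longer chain such as ethyl, or a ring such as cyclopropyl, on this nitrogen would hold the reading stays open. The read-out at one concentration also leaves the potency of compound 3 and compound 4 open.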